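Swapping a butyl for an ethoxy in the longest chain

The source may report more compounds than this note shows. Statements on the series, on what has been measured and on what is new or still open speak of the compounds shown alone.

Among the compounds with values here, in a functional assay on A549 cells (Homo sapiens) for inhibition, read by sulforhodamine B assay, with a stated time of 72 h (on this read-out lower numbers stand for stronger inhibition and higher numbers for weaker inhibition), compound 1 `COc1cc2c(Nc3ccc(F)c(Cl)c3)ncnc2cc1OCCCn1ccnc1[N+](=O)[O-]` gives 5910 nM, while compound 2 `COc1cc2c(Nc3ccc(F)c(Cl)c3)ncnc2cc1OCCCCCCn1ccnc1[N+](=O)[O-]` gives 13400 nM, the highest number so far and therefore the weaker inhibition of the pair. Compound 3 `COc1cc2c(Nc3ccc(F)c(Cl)c3)ncnc2cc1OCCOCCn1ccnc1[N+](=O)[O-]` departs from compound 2 in a single place, on a saturated chain carbon, two bonds along the chain from an oxygen on an aromatic ring: 2-(2-nitro-1H-imidazol-1-yl)ethoxy in place of 4-(2-nitro-1H-imidazol-1-yl)butyl on a saturated chain carbon, two bonds along the chain from an oxygen on an aromatic ring. Within the data shown here, only one measured step bears on this change, a 2.3-fold higher number from compound 1 to compound 2 (0.36 log units; beyond the scatter), which is modest and arose within the same chain. Among the measured compounds shown here, no measured compound yet carries the ethoxy group, so the guide is indirect. On the strength of that step, a small move towards a lower number is expected in this assay, possibly no larger than the scatter. The estimated change is a 1.5-fold lower number from compound 2 to compound 3 (0.17 log units; within the scatter). For compound 3 the expected value is 9000 nM, within an estimated range of 4000 nM to 18000 nM.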

Compound 3, half-maximal inhibitory concentration: 12900 nM
Compound 3: middle estimate off by 1.4-fold (0.16 log units), on the low side; the range from low to high includes it.
By their numbers in this assay, from the lowest: compound 1; then compounds 3 and 2 (each within the scatter of the next).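

In this assay, the exchange of 4-(2-nitro-1H-imidazol-1-yl)butyl for 2-(2-nitro-1H-imidazol-1-yl)ethoxy at this position leaves compound 2 and compound 3 within the scatter of each other (a 1.0-fold lower number from compound 2 to compound 3 (0.02 log units; within the scatter)), so an oxygen in the chain in place of a saturated carbon, with one heavy atom fewer in the group, shows no measurable effect here. Compound 1, with the shorter chain, keeps its distance from the ether-linked compound as well (a 2.2-fold higher number from compound 1 to compound 3 (0.34 log units; beyond the scatter)), so both of the longer chains stand apart from it by a similar, modest step. Nothing measured accounts for either observation.

From the compounds shown here alone, it remains open whether an amine in the same chain position would read like the ether oxygen or the saturated carbon. Going by these compounds, how a longer chain, or a chain ending in a morpholine in place of the 2-nitroimidazole, would read also remains unknown.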